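This account rests on a few compounds, and the source may have more. Where it says the series, first, only, none or still open, it means among the compounds named here.

Measured compounds:
- compound 1 `CN(CC1=CC[C@H]2C[C@@H]1C2(C)C)Cc1ccc(Cl)cc1`, in an assay on HEK293 cells for displacement of a labelled ligand from C-X-C chemokine receptor type 3 (Homo sapiens) (a higher number here means a weaker inhibitor, a lower number a stronger inhibitor), compound 1 gives 2510 nM
- compound 2 `CN(CC1=CC[C@H]2C[C@@H]1C2(C)C)Cc1ccc(Br)cc1`, in this assay compound 2 gives 3160 nM

For the measured compounds named here, compound 1 has the lowest of the two numbers obtained so far, but the only step available, a 1.3-fold higher number from compound 1 to compound 2 (0.10 log units; within the scatter), lies within the scatter, so compound 1 and compound 2 cannot be told apart on these numbers.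

Compound 3 `CN(CC1=CC[C@H]2C[C@@H]1C2(C)C)Cc1ccc(Cl)c(Cl)c1` keeps the whole core of compound 1 and differs from it in one place: chloro in place of hydrogen on an aromatic carbon. This is the introduction of a second chloro group onto the ring that already carries one.

Going by the values given here, the one measured step bears on it only indirectly: exchanging chloro for bromo, in a 1.3-fold higher number from compound 1 to compound 2 (0.10 log units; within the scatter), left the number where it was. Among the compounds with values here, no measured pair shows what adding a second halogen does. With so little to go on, the expectation for compound 3 in this assay is a step of about a 1.3-fold lower number from compound 1 to compound 3 (0.10 log units; within the scatter) from compound 1, that is, nothing clearly beyond the scatter.

Compound 3 is therefore estimated at 2000 nM, with a range from 800 nM to 5000 nM.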

Compound 3, inhibition constant: 3160 nM
Compound 3: middle estimate off by 1.6-fold (0.20 log units), on the low side; measured number inside the range.
By their numbers in this assay, from the lowest: compounds 1, 2 and 3 (each within the scatter of the next).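

In this assay, placing a chloro group on the aromatic carbon ortho to the existing chloro group and meta to a large group gives a 1.3-fold higher number from compound 1 to compound 3 (0.10 log units; within the scatter) and so leaves compound 3 indistinguishable from compound 1 on these numbers. The earlier compounds shown here showed only one halogen exchanged for another at a single ring carbon, whereas this pair shows that adding a group at a second ring carbon, where there was only hydrogen, also produces no change that can be separated from the scatter of repeated measurements. No measurement of any other kind is available to explain this result.

As far as these compounds go, it remains open whether this carbon is generally insensitive to what it carries, or whether an amine, a carboxylic acid or a longer chain there would shift the number clearly beyond the scatter. The compounds shown also cannot say what happens when the chloro group of compound 1 is replaced by hydrogen, so the contribution of that first halogen is still unknown.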